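This account rests on a few compounds, and the source may have more. Where it says the series, first, only, none or still open, it means among the compounds named here.

Measured so far in an ADME assay on Raji cells (Homo sapiens) for cytotoxicity, read by luminescence, with a stated time of 72 h; on this read-out higher numbers stand for an effect only at larger amounts of compound and lower numbers for an effect already at smaller amounts:
- compound 1 `CCOC(=O)c1c(-c2cccc(OCC)c2)[nH]c2cc(OC)ccc2c1=O`: > 21500 nM, a limit of the assay
- compound 2 `CCOC(=O)c1c(-c2cccc(OCC(C)C)c2)[nH]c2cc(OC)ccc2c1=O`: > 21500 nM, a limit of the assay

Compound 2 therefore stands at the upper edge of what this assay reports, with no number of its own. The comparison with compound 1 is a step that the two limits leave unreadable from compound 1 to compound 2, so the exchange of isopropyl for methyl on the saturated chain carbon bound to the ring oxygen tells nothing about direction or size; the only fixed point is the limit of > 21500 nM in this assay, at which 2 of the 2 values shown sit.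

Compound 3 `CCOC(=O)c1c(-c2cccc([N+](=O)[O-])c2)[nH]c2cc(OC)ccc2c1=O` differs from compound 2 by nitro in place of isobutoxy on an aromatic carbon. Going by the values given here, no measured step bears on this change, and both values at hand are limits, so no size of step in this assay can be read from them. The expectation is that compound 3 again gives no readable number, the implied step a number no higher from compound 2 to compound 3 (the limit leaves the size open) being expected to stay within the scatter. Compound 3 is estimated at 21500 nM, between 7000 nM and 60000 nM.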

Compound 3, half-maximal effective concentration: > 21500 nM
Compound 3: only a limit was reported (the forecaster's own chance of this, stated with the estimate: 70%); the middle value lies on the limit itself.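

Compound 3 adds no readable step in this assay, and its comparisons with compound 1 and compound 2 cannot be read, the position being: the limit of > 21500 nM in this assay, at which 3 of the 3 values shown sit.

The compounds shown leave open whether ethoxy, isobutoxy or nitro differ at all in this read-out, and in which direction.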